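The source may report more compounds than this note shows. Statements on the series, on what has been measured and on what is new or still open speak of the compounds shown alone.

Working notes on the series. Compound 1 `CC(=O)N1CC=C(c2ccn3c(-c4ccc(NC(=O)c5ccc([N+](=O)[O-])o5)cc4)cnc3c2)CC1` and compound 2 `O=C(Nc1ccc(-c2cnc3cc(C4=CCN(C5COC5)CC4)ccn23)cc1)c1ccc([N+](=O)[O-])o1` share one core and differ only in what sits on the amine nitrogen in a ring. In a functional assay on AGS cells (Homo sapiens) for antiproliferative activity, read by CCK-8 assay, with a stated time of 72 h (on this read-out lower numbers stand for stronger inhibition and higher numbers for weaker inhibition), compound 1 gives 410 nM. In this assay, among the compounds with values here, compound 2 gives 790 nM, the higher of the two numbers recorded so far, with compound 1 as its only neighbour; the step of a 1.9-fold higher number from compound 1 to compound 2 (0.28 log units; within the scatter) falls within the scatter, so the two compounds are not separated on this read-out.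

Compound 3 `O=C(Nc1ccc(-c2cnc3cc(Br)ccn23)cc1)c1ccc([N+](=O)[O-])o1` is the unmeasured member. Relative to compound 2 it shows (one bromine atom in place of a group of 10 heavy atoms (8 carbon, 1 nitrogen, 1 oxygen; one four-membered non-aromatic ring with 1 hetero atom, one six-membered non-aromatic ring with 1 hetero atom), on an aromatic carbon). Within the data shown here, the only measured step, a 1.9-fold higher number from compound 1 to compound 2 (0.28 log units; within the scatter), concerns a change on the amine nitrogen of the very group that is replaced here, so no measured step speaks directly to this exchange; the two numbers set only the starting point. A step beyond the scatter in this assay, toward a higher number, is expected, with wide uncertainty. Compound 3 is expected to give 1600 nM, in the range 400 nM to 6500 nM, an expected step of a 2.0-fold higher number from compound 2 to compound 3 (0.31 log units; beyond the scatter) in this assay.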

Compound 3, half-maximal inhibitory concentration: 560 nM
Compound 3: the middle estimate sits 2.9-fold (0.46 log units) above what was measured, and the stated range covers the measured number.
By their numbers in this assay, from the lowest: compounds 1, 3 and 2 (each within the scatter of the next).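

In this assay, the whole group of 10 heavy atoms on this aromatic carbon, opposite the ring nitrogen, can be exchanged for bromo without separating the compounds: the exchange gives a 1.4-fold lower number from compound 2 to compound 3 (0.15 log units; within the scatter), and the comparison with the acetyl-bearing compound gives a 1.4-fold higher number from compound 1 to compound 3 (0.14 log units; within the scatter). The earlier pair spoke only to the substituent on the amine nitrogen, whereas these steps show that the six-membered non-aromatic ring itself is not required to keep the read-out within the scatter of compound 1 and compound 2. Nothing available explains this result.

Open, as far as these compounds go, is whether this position is insensitive to substitution generally or only across these three groups. A carboxylic acid or a primary amine on the same aromatic carbon would test that directly, as would plain hydrogen in place of bromo.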